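Moving the Hydroxyl on a Pyridine-Linked Phenol

The compounds below may be only part of what the source reports. "The series", "measured", "known", "first", "only" and "open" are said of these compounds alone.

Measured so far:
compound 1, `Oc1ccc(-c2cc(-c3ccc(Cl)cc3)nc(-c3cccnc3)c2)cc1` — 20700 nM
compound 2, `Oc1cccc(-c2cc(-c3ccccc3)nc(-c3ccc(Cl)cc3)c2)c1` — 8110 nM

Of the compounds shown here, two have been measured in a functional assay on HCT-15 cells (Homo sapiens) for cytotoxicity, read by CCK-8 assay and cell counting, with a stated time of 2 days; a higher number here means a weaker inhibitor, a lower number a stronger inhibitor. Compound 1, `Oc1ccc(-c2cc(-c3ccc(Cl)cc3)nc(-c3cccnc3)c2)cc1`, gives 20700 nM. Compound 2, `Oc1cccc(-c2cc(-c3ccccc3)nc(-c3ccc(Cl)cc3)c2)c1`, gives 8110 nM, the lower of the two numbers; the gap to compound 1 is beyond the scatter of repeated runs, so compound 2 is the stronger of the pair on the numbers in hand. The two differ in more than one place, so no single step can be read from them.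

Compound 3, `Oc1ccc(-c2cc(-c3ccccc3)nc(-c3ccc(Cl)cc3)c2)cc1`, is not yet measured. It differs from compound 2 in one place: 4-hydroxyphenyl in place of 3-hydroxyphenyl on an aromatic carbon. The same atoms are present, joined differently. Within the data shown here, nothing in the measured pair isolates this change, so the author has no step to lean on; the expectation in this assay is a small step from compound 2, direction uncertain, possibly none beyond the scatter. The estimated step from compound 2 to compound 3 is a 1.5-fold higher number from compound 2 to compound 3 (0.17 log units; within the scatter). Compound 3 is expected to give about 12000 nM, in a range from 4000 nM to 40000 nM.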

Compound 3, half-maximal inhibitory concentration: 6920 nM
Compound 3: the middle estimate sits 1.7-fold (0.24 log units) above what was measured, and the stated range covers the measured number.
By their numbers in this assay, from the lowest: compounds 3 and 2 (each within the scatter of the next); then compound 1.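

In this assay, 4-hydroxyphenyl in place of 3-hydroxyphenyl, on the aromatic carbon opposite the ring nitrogen, gives a 1.2-fold lower number from compound 2 to compound 3 (0.07 log units; within the scatter) and so leaves the two hydroxyl placements indistinguishable in this assay. Compound 3 also makes possible a comparison that the earlier pair could not offer: phenyl in place of pyridin-3-yl on an aromatic carbon gives a 3.0-fold lower number from compound 1 to compound 3 (0.48 log units; beyond the scatter) and is the one single-place change shown here that clears the scatter, though only modestly. No supporting measurement is available to explain either step.

The compounds shown leave open whether the hydroxyl itself matters at this position, which a methoxy group, an amine or a carboxylic acid on the same phenyl ring would begin to test. They also leave open how far the modest step for phenyl in place of pyridin-3-yl would hold with 3-hydroxyphenyl on the shared core, and whether a group such as a methyl or a fluorine in place of the chlorine of the 4-chlorophenyl group would move the number at all.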